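The source may hold more compounds than are shown below. What is called first, only, known or untested is meant among the compounds shown, and "the series" means these compounds.

Working notes on the series. In an assay on HEK293 cells for displacement of a labelled ligand from NPC1-like intracellular cholesterol transporter 1 (Homo sapiens) (on this read-out lower numbers stand for stronger inhibition and higher numbers for weaker inhibition), compound 1 `CCOC(=O)C1CCN(C(=O)CN2CN(c3ccccc3)C3(CCN(C(=O)c4ccc(C5CCCCC5)cc4)CC3)C2=O)CC1` gives 900 nM, compound 2 `O=C(CN1CN(c2ccccc2)C2(CCN(C(=O)c3ccc(C4CCCCC4)cc3)CC2)C1=O)N1CCCCC1` gives 1100 nM, and compound 3 `CC(C)(C)OC(=O)NCCCCNC(=O)CN1CN(c2ccccc2)C2(CCN(C(=O)c3ccc(C4CCCCC4)cc3)CC2)C1=O` gives 4600 nM. The step of a 1.2-fold higher number from compound 1 to compound 2 (0.09 log units; within the scatter) lies within the scatter. Compound 3 stands highest of the three, beyond the scatter from both compound 1 and compound 2.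

Compound 4 `O=C(CN1CN(c2ccccc2)C2(CCN(C(=O)c3ccc(C4CCCCC4)cc3)CC2)C1=O)NCCCCO` differs from compound 3 by hydroxy in place of (tert-butoxycarbonyl)amino on a saturated chain carbon, four bonds along the chain from an amide-type nitrogen. Among the measured compounds shown here, no measured step bears directly on this change: the single step available removes a carbonyl-bearing group from a saturated ring carbon, not from a chain, and stays within the scatter. Compound 2, with a small amide terminus, sits well below compound 3, so a smaller amide terminus in compound 4 is expected to pull the number down. The step of a 1.8-fold lower number from compound 3 to compound 4 (0.26 log units; within the scatter) is therefore expected downward, its size uncertain. For compound 4 the estimate in this assay is 2500 nM, range 900 nM to 7000 nM.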

Compound 4, half-maximal inhibitory concentration: 10300 nM
Compound 4: the middle estimate sits 4.1-fold (0.61 log units) below what was measured; the measured number lies above the stated range.
By their numbers in this assay, from the lowest: compounds 1 and 2 (each within the scatter of the next); then compound 3; then compound 4.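

At this position on the chain, the smaller hydroxy gives no gain over the (tert-butoxycarbonyl)amino group: the number moves up (a 2.2-fold higher number from compound 3 to compound 4 (0.35 log units; beyond the scatter)). A small terminus alone therefore does not bring the low numbers, since the (4-hydroxybutyl)amino end stands well above both the piperidin-1-yl end (a 9.4-fold higher number from compound 2 to compound 4 (0.97 log units; beyond the scatter)) and the 4-(ethoxycarbonyl)piperidin-1-yl end (an 11-fold higher number from compound 1 to compound 4 (1.06 log units; beyond the scatter)). Nothing available explains these rises. Open, on these data alone, is whether the hydroxy itself or the open chain sets the number. A free amine or a carboxylic acid at the chain end, or a longer chain carrying hydroxy, would separate the two.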